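Para substituent of the anilino ring in this series

The compounds below may be only part of what the source reports. "The series", "measured", "known", "first", "only" and "open" are said of these compounds alone.

Compound 3 `N#Cc1c(Nc2ccc(Cl)cc2)nc(SCc2cn(Cc3ccccc3Cl)nn2)nc1-c1ccccc1` gives the lowest of the two numbers shown, 1420 nM in a functional assay on ECa-109 cells (Homo sapiens) for inhibition, read by MTT assay, with a stated time of 72 h; a lower number here means a stronger inhibitor, a higher number a weaker inhibitor. Compound 1 `C#CCSc1nc(Nc2ccc(OC)cc2)c(C#N)c(-c2ccccc2)n1` gives 23200 nM in this assay. Compound 2 `C#CCSc1nc(Nc2ccc(Cl)cc2)c(C#N)c(-c2ccccc2)n1` reaches only a limit of this assay, > 128000 nM. Within the data shown here, the one measured step, an at least 5.5-fold higher number from compound 1 to compound 2 (0.74 log units; beyond the scatter), is a higher number whose size reflects (the limit of > 128000 nM in this assay, at which 1 of the 3 values shown sits). Compound 4 `Cc1ccc(Nc2nc(SCc3cn(Cc4ccccc4Cl)nn3)nc(-c3ccccc3)c2C#N)cc1` differs from compound 3 by methyl in place of chloro on an aromatic carbon. The measured step exchanged methoxy for chloro, not chloro for methyl, and bears on this change only loosely; no step beyond the scatter is expected. Compound 4 is therefore expected to give 1000 nM (range 300 nM to 4000 nM), which would mean an expected step of a 1.4-fold lower number from compound 3 to compound 4 (0.15 log units; within the scatter).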

Compound 4, half-maximal inhibitory concentration: > 64000 nM
Compound 4 was reported as a limit; the forecaster's own chance of this, stated with the estimate: 5%; middle value at least 64-fold (1.80 log units) from the limit.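

In this assay, with the side chain of compound 3 held constant, this one-atom exchange is far from neutral: an at least 45-fold higher number from compound 3 to compound 4 (1.65 log units; beyond the scatter). Chloro lies on the lower-number side here but on the higher-number side in an at least 5.5-fold higher number from compound 1 to compound 2 (0.74 log units; beyond the scatter), where the side chain on sulfur differs, so no single ranking of this substituent holds across both pairs. Compound 4 is a limit, so the full size of its step stays open: the limit of > 64000 nM in this assay, at which 1 of the 4 values shown sits.

As far as these compounds go, whether the lower number is particular to chloro remains open. Bromo or an amino group on the same carbon, with the side chain of compound 3, would test this.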